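This account rests on a few compounds, and the source may have more. Where it says the series, first, only, none or still open, it means among the compounds named here.

Measured in this set:
Compound 1 `Cc1ccc(C2C(C#N)=C(N)N(c3ccc(S(N)(=O)=O)cc3)C3=C2CCCC3)cc1`: 20%
Compound 2 `N#CC1=C(N)N(c2ccc(S(N)(=O)=O)cc2)C2=C(CCCC2)C1c1ccccc1O`: 10%
Compound 3 `N#CC1=C(N)N(c2ccc(S(N)(=O)=O)cc2)C2=C(CCCC2)C1c1ccc(Cl)cc1Cl`: 0%

In a functional assay on Ehrlich cells (Mus musculus) for cytotoxicity, read by trypan blue exclusion, with a stated time of 2 h, tested at 10 ug/mL (on this read-out higher numbers stand for a stronger effect at the one concentration tested and lower numbers for a weaker effect), compound 3 stands apart from compound 1 beyond the scatter, as the step of a number 20 percentage points lower from compound 1 to compound 3 (beyond the scatter) shows, but not from compound 2, since a number 10 percentage points lower from compound 2 to compound 3 (within the scatter) lies within the scatter. Compound 4 `N#CC1=C(N)N(c2ccc(S(N)(=O)=O)cc2)C2=C(CCCC2)C1c1ccc(Cl)c(Cl)c1` differs from compound 3 only by 3,4-dichlorophenyl in place of 2,4-dichlorophenyl on a saturated ring carbon. All three measured steps swap the aryl group on that same saturated ring carbon, and even the largest, a number 20 percentage points lower from compound 1 to compound 3 (beyond the scatter), was modest; the step of a number 10 percentage points lower from compound 1 to compound 2 (within the scatter) stayed within the scatter. Moving from one dichlorophenyl to another is expected to give no step beyond the scatter, a number 5 percentage points higher from compound 3 to compound 4 (within the scatter). For compound 4 the expected value is 5%, within 0% to 20%.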

Compound 4, a percentage reported as activity, at one concentration (the size of the read-out at that concentration, not a potency): 1%
For compound 4 the middle estimate is 4 percentage points above the measured one; the measured number falls inside the stated range.
By their numbers in this assay, from the lowest: compounds 3, 4, 2 and 1 (each within the scatter of the next, the first and the last beyond it).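

In this assay the swap of chlorine pattern gives a number 1 percentage points higher from compound 3 to compound 4 (within the scatter) and so does not separate the 2,4-dichlorophenyl and 3,4-dichlorophenyl groups on this saturated ring carbon. The 3,4-dichlorophenyl group behaves like its isomer against the other two aryl groups: a number 9 percentage points lower from compound 2 to compound 4 (within the scatter) stays within the scatter, whereas a number 19 percentage points lower from compound 1 to compound 4 (beyond the scatter) goes beyond it, though only modestly. Nothing available explains these steps. Still open, on these data alone, is how an aryl group carrying an amine or a carboxylic acid would read at this carbon, and whether any group here could give a clearly larger effect than compound 1 shows.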